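The source may hold more compounds than are shown below. What is called first, only, known or untested is meant among the compounds shown, and "the series" means these compounds.

Within the data shown here, compound 2, with the structure `Cc1cn2c(-c3cn[nH]c3)cnc2c(Nc2cc(Cc3cccc(F)n3)ns2)n1`, stands highest of the two numbers so far: in an ADME assay on the whole organism for pharmacokinetics, with Rattus norvegicus as the target, with a stated time of 6 h, at a dose of 10 mg/kg by the oral route (on this read-out lower numbers stand for lower exposure and higher numbers for higher exposure at the dose given), compound 2 gives 2970 ng.h/mL. Its nearest neighbour is compound 1, with the structure `Cc1ccnc(Cc2cc(Nc3nc(C)cn4c(-c5cn[nH]c5)cnc34)sn2)c1`, which in this assay gives 1850 ng.h/mL; the step of a 1.6-fold higher number from compound 1 to compound 2 (0.21 log units; within the scatter) lies within the scatter of repeated measurements.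

Compound 3, with the structure `COc1cccc(Cc2cc(Nc3nc(C)cn4c(-c5cn[nH]c5)cnc34)sn2)n1`, is reached from compound 2 by a single change: methoxy in place of fluoro on an aromatic carbon. Among the measured compounds shown here, the only measured step available, a 1.6-fold higher number from compound 1 to compound 2 (0.21 log units; within the scatter), also exchanged the group carried on the saturated chain carbon bound to an aromatic carbon, and that exchange moved the exposure by an amount indistinguishable from noise. On that basis the change from fluoro to methoxy is expected to give a step of no more than the usual scatter, in either direction, so compound 3 is estimated to show a 1.4-fold lower number from compound 2 to compound 3 (0.13 log units; within the scatter) relative to compound 2.

The expected value for compound 3 in this assay is therefore 2200 ng.h/mL, with a range from 900 ng.h/mL to 5500 ng.h/mL.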

Compound 3, area under the concentration-time curve: 2300 ng.h/mL
For compound 3 the middle estimate is 1.0-fold (0.02 log units) below the measured one, and the stated range covers the measured number.
By their numbers in this assay, from the lowest: compounds 1, 3 and 2 (each within the scatter of the next).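

In this assay, putting methoxy in place of fluoro on the aromatic carbon next to the ring nitrogen gives a 1.3-fold lower number from compound 2 to compound 3 (0.11 log units; within the scatter), so this position takes a group with one more heavy atom and a hydrogen-bond acceptor without a step beyond the scatter. The comparison with the 4-methylpyridin-2-yl group of the first compound gives the same kind of result, a 1.2-fold higher number from compound 1 to compound 3 (0.09 log units; within the scatter), so the 4-methylpyridin-2-yl, 6-fluoropyridin-2-yl and 6-methoxypyridin-2-yl groups now form a set of three whose exposures cannot be told apart in this read-out. Nothing at hand gives a reason for this closeness.

From the compounds shown here alone, whether an amine or a carboxylic acid on this same ring carbon, or a longer chain such as ethoxy in place of methoxy, would carry the exposure beyond the scatter remains open. Going by these compounds, all three compounds also keep the same core and the same saturated chain carbon bearing the ring, so the effect of a change in those places on exposure remains open too.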